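Anilino in place of cyclohexylamino: notes on the series

The source may hold more compounds than are shown below. What is called first, only, known or untested is meant among the compounds shown, and "the series" means these compounds.

The series shares one core, carried by compound 1 `O=C1C(Nc2ccccc2F)=CC(=O)c2c1nc1n2[C@H]2OC[C@@H](O)[C@H]2OC1`, compound 2 `O=C1C=C(NC2CCCCC2)C(=O)c2c1nc1n2[C@H]2OC[C@@H](O)[C@H]2OC1` and the still unmeasured compound 3 `O=C1C=C(Nc2cccc(Cl)c2)C(=O)c2c1nc1n2[C@H]2OC[C@@H](O)[C@H]2OC1`, and varies only in the substituent on the amine nitrogen. In a functional assay on ECa-109 cells for inhibition, with ECa-109 cell line (Homo sapiens) as the target, read by sulforhodamine B assay (a lower number here means a stronger inhibitor, a higher number a weaker inhibitor), compound 1 gives 2660 nM. Compound 2 reaches only the limit of this assay, > 16000 nM, so for compound 2 no number is known, only that it sits at that limit (the limit of > 16000 nM in this assay, at which 1 of the 2 values shown sits). Within the data shown here, no single step is drawn between compound 1 and compound 2; what the two values show is that compound 1 has a number and compound 2 only a limit.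

Compound 3 carries the change (3-chlorophenyl in place of cyclohexyl on an amine nitrogen). Among the measured compounds shown here, no measured step covers this pair. Compound 1 gives 2660 nM in this assay with an aryl group on the amine nitrogen, and compound 3 shares that feature. The step of an at least 5.3-fold lower number from compound 2 to compound 3 (0.72 log units; beyond the scatter) is therefore expected to be a gain clearly beyond the scatter. Compound 3 is estimated at 3000 nM, with a range from 800 nM to 12000 nM.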

Compound 3, half-maximal inhibitory concentration: 4690 nM
Compound 3: middle estimate off by 1.6-fold (0.19 log units), on the low side, within the range that was stated.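

Among these compounds, the change from cyclohexyl to 3-chlorophenyl on the amine nitrogen gives an at least 3.4-fold lower number from compound 2 to compound 3 (0.53 log units; beyond the scatter) in this assay, and this is the only step so far that compares two measured compounds differing in one place. It shows that, on this amine nitrogen and with the rest of the molecule held fixed, the 3-chlorophenyl group gives a measurable number where the cyclohexyl group does not, as compound 3 gives 4690 nM. The size of the step is a bound and not a measured gap, so the real distance between the two groups may be larger: the limit of > 16000 nM in this assay, at which 1 of the 3 values shown sits.

The change swaps a six-membered non-aromatic ring of carbon for a six-membered aromatic ring and adds a chlorine in the same move, so the compounds shown do not separate the contribution of the ring from that of the chlorine, which a plain phenyl group on the same nitrogen would do. Also open, on these data alone, is how a benzyl group or an open alkyl chain such as n-butyl would read at this position.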